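Chloro on the pendant phenyl of the ethoxy analogue

The source may hold more compounds than are shown below. What is called first, only, known or untested is meant among the compounds shown, and "the series" means these compounds.

Compound 1 `COc1ccc2c(c1)OC(c1ccc([N+](=O)[O-])cc1)C(c1ccccc1)C2=O`: in a functional assay (on this read-out higher numbers stand for an effect only at larger amounts of compound and lower numbers for an effect already at smaller amounts), compound 1 gives only a limit, > 2500000 nM (the limit of > 2500000 nM in this assay, at which 1 of the 3 values shown sits).
Compound 2 `COc1ccc2c(c1)OC(c1ccc(Cl)cc1)C(c1ccccc1)C2=O`: in this assay compound 2 gives 165000 nM.
Compound 3 `CCOc1ccc2c(c1)OC(c1ccccc1)C(c1ccccc1)C2=O`: in this assay compound 3 gives 877000 nM.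

Of the two actual numbers, compound 3 stands highest, with compound 2 as its nearest neighbour at a separation beyond the scatter. Compound 4 `CCOc1ccc2c(c1)OC(c1ccc(Cl)cc1)C(c1ccccc1)C2=O` differs from compound 3 by chloro in place of hydrogen on an aromatic carbon. Within the data shown here, the only measured step on that ring is an at least 15-fold lower number from compound 1 to compound 2 (1.18 log units; beyond the scatter), a swap of nitro for chloro rather than hydrogen for chloro, so it bears on the present change only indirectly. For compound 4 a step of a 2.9-fold lower number from compound 3 to compound 4 (0.47 log units; beyond the scatter) toward lower numbers is expected. Compound 4 is estimated at 300000 nM, within 70000 nM to 1300000 nM.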

Compound 4, half-maximal effective concentration: 578000 nM
Compound 4: middle estimate off by 1.9-fold (0.28 log units), on the low side; the range from low to high includes it.
By their numbers in this assay, from the lowest: compound 2; then compounds 4 and 3 (each within the scatter of the next). At a limit, above all of these: compound 1.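

In this assay, on the ethoxy analogue, phenyl to 4-chlorophenyl gives no change that can be told from the scatter (a 1.5-fold lower number from compound 3 to compound 4 (0.18 log units; within the scatter)). With chloro in place, the chain on the oxygen does register: methyl in place of hydrogen there gives a step beyond the scatter (a 3.5-fold higher number from compound 2 to compound 4 (0.54 log units; beyond the scatter)). Nothing at hand accounts for either step.

From the compounds shown here alone, whether chloro in place of hydrogen behaves the same on the methoxy analogue stays open. Also open, going by these compounds, are an amine or a carboxylic acid on the pendant phenyl, and a longer chain in place of ethoxy.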